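This account rests on a few compounds, and the source may have more. Where it says the series, first, only, none or still open, it means among the compounds named here.

Measured values in a functional assay on A549 cells (Homo sapiens) for antiproliferative activity, read by CCK-8 assay, with a stated time of 72 h; on this read-out lower numbers stand for stronger inhibition and higher numbers for weaker inhibition:

compound 1 `O=C(Nc1cccc(-c2oc3cc(-c4ccc(F)cc4)ccc3c(=O)c2O)c1)c1ccc(Cl)cc1` — 10800 nM
compound 2 `CCc1ccc(C(=O)Nc2cccc(-c3oc4cc(-c5ccc(F)cc5)ccc4c(=O)c3O)c2)cc1` — 18500 nM
compound 3 `N#Cc1ccc(C(=O)Nc2cccc(-c3oc4cc(-c5ccc(F)cc5)ccc4c(=O)c3O)c2)cc1` — 2360 nM

Compound 1 stands second highest of the three numbers. Its nearest neighbour is compound 2, with a 1.7-fold higher number from compound 1 to compound 2 (0.23 log units; within the scatter), a difference that cannot be read as a real change. Its furthest neighbour is compound 3, with a 4.6-fold lower number from compound 1 to compound 3 (0.66 log units; beyond the scatter), the one clear movement in the set; the same carbon also carries a 7.8-fold lower number from compound 2 to compound 3 (0.89 log units; beyond the scatter).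

Compound 4 `O=C(Nc1cccc(-c2oc3cc(-c4ccc(F)cc4)ccc3c(=O)c2O)c1)c1ccc([N+](=O)[O-])cc1` is the next single-point change at that same aromatic carbon: nitro in place of chloro on an aromatic carbon. Two of the three measured steps bear on it. Among the compounds with values here, the exchange of chloro for ethyl left the number where it was, while the exchange of chloro for cyano lowered it to a modest but real degree; no nitro-bearing compound has yet been measured, so the step of compound 1 to compound 4 is not directly read anywhere. Given that the one substituent which did shift the number, in compound 3, gave a 4.6-fold lower number from compound 1 to compound 3 (0.66 log units; beyond the scatter), the expectation for compound 4 in this assay is a lower number than compound 1, of a modest size, with a real chance that the step stays within the scatter.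

The estimated step is a 2.4-fold lower number from compound 1 to compound 4 (0.38 log units; beyond the scatter), and compound 4 is expected to give 4500 nM, with a range from 1500 nM to 13000 nM.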

Compound 4, half-maximal inhibitory concentration: 2440 nM
For compound 4 the middle estimate is 1.8-fold (0.27 log units) above the measured one, within the range that was stated.
By their numbers in this assay, from the lowest: compounds 3 and 4 (each within the scatter of the next); then compounds 1 and 2 (each within the scatter of the next).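

In this assay nitro in place of chloro gives a 4.4-fold lower number from compound 1 to compound 4 (0.65 log units; beyond the scatter) and, against ethyl, a 7.6-fold lower number from compound 2 to compound 4 (0.88 log units; beyond the scatter) in the same assay, so the drop seen with cyano is no longer a single case at this aromatic carbon. Nitro and cyano cannot be told apart here, with a 1.0-fold higher number from compound 3 to compound 4 (0.01 log units; within the scatter) as their step, and the four compounds therefore fall into two pairs, compounds 3 and 4 on the lower side and compounds 1 and 2 on the higher side, with no compound among the four going against that split. Nothing measured alongside these numbers accounts for the split, which stands as an observation on four compounds only.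

The compounds shown leave open where an amine, a carboxylic acid, a methoxy group or plain hydrogen at this carbon would fall, and whether any of them would join one of the two pairs or sit apart from both. They also leave open whether the same split between the pairs holds when the 4-fluorophenyl part of the shared core carries another group, such as a longer chain.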